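The source may report more compounds than this note shows. Statements on the series, on what has been measured and on what is new or still open speak of the compounds shown alone.

In a functional assay on A20 cells (Mus musculus) for inhibition, with stated times of 1 h, 16 h and 24 h (a lower number here means a stronger inhibitor, a higher number a weaker inhibitor), compound 1 `N#CC1(NC(=O)[C@@H]2C[C@@H](S(=O)(=O)c3ccccc3)C[C@H]2C(=O)N2CCOCC2)CC1` gives 12 nM and compound 2 `CC1CCN(C(=O)[C@@H]2C[C@H](S(=O)(=O)c3ccccc3)C[C@H]2C(=O)NC2(C#N)CC2)CC1` gives 2 nM while compound 3 `N#CC1(NC(=O)[C@@H]2C[C@@H](S(=O)(=O)c3ccccc3)C[C@H]2C(=O)N2CCS(=O)(=O)CC2)CC1` stands highest at 816 nM as the weakest inhibitor of the three. Compound 4 `N#CC1(NC(=O)[C@@H]2C[C@@H](S(=O)(=O)c3ccccc3)C[C@H]2C(=O)N2CC(O)C2)CC1` keeps the shared core and alters only the group on the carbonyl carbon: 3-hydroxyazetidin-1-yl in place of 1,1-dioxothiomorpholin-4-yl on a carbonyl carbon (3-hydroxyazetidin-1-yl in place of 1,1-dioxothiomorpholin-4-yl). Both measured steps that enter 1,1-dioxothiomorpholin-4-yl bear on this change: a 68-fold higher number from compound 1 to compound 3 (1.83 log units; beyond the scatter) and a 410-fold higher number from compound 2 to compound 3 (2.61 log units; beyond the scatter) are large, whereas a 6.0-fold lower number from compound 1 to compound 2 (0.78 log units; beyond the scatter) is modest. For the measured compounds named here, no measured compound carries 3-hydroxyazetidin-1-yl, so the size remains uncertain. The expected step in this assay is a 14-fold lower number from compound 3 to compound 4 (1.13 log units; beyond the scatter) and goes to a lower number beyond the scatter. The estimate for compound 4 is 60 nM (expected range 12 nM to 300 nM).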

Compound 4, half-maximal inhibitory concentration: 572 nM
Compound 4: the middle estimate sits 9.5-fold (0.98 log units) below what was measured, outside the stated range (above it).
By their numbers in this assay, from the lowest: compound 2; then compound 1; then compounds 4 and 3 (each within the scatter of the next).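

In this assay, a 1.4-fold lower number from compound 3 to compound 4 (0.15 log units; within the scatter), so 3-hydroxyazetidin-1-yl and 1,1-dioxothiomorpholin-4-yl on a carbonyl carbon cannot be told apart, despite their different ring sizes. With a 48-fold higher number from compound 1 to compound 4 (1.68 log units; beyond the scatter) and a 290-fold higher number from compound 2 to compound 4 (2.46 log units; beyond the scatter), the large rise in the number at this position is no longer confined to 1,1-dioxothiomorpholin-4-yl. No supporting data are available to account for this result. Still open, as far as these compounds go, is whether plain azetidin-1-yl, without the hydroxyl, would fall with these two groups, and whether unsubstituted piperidin-1-yl would fall with 4-methylpiperidin-1-yl.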